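Acylsulfonamide in place of the urea on the core

This account rests on a few compounds, and the source may have more. Where it says the series, first, only, none or still open, it means among the compounds named here.

Compound 3 `CCNC(=O)Nc1ccc2c(cnn2CC(=O)COc2ccc(Oc3ccccc3)cc2)c1` stands second highest of the three numbers in an assay on microsomes from brain for inhibition of Fatty-acid amide hydrolase 1 (Rattus norvegicus), read by fluorescence and HPLC, with a stated time of 45 min; a higher number here means a weaker inhibitor, a lower number a stronger inhibitor: compound 3 gives 1600 nM, compound 2 `O=C(COc1ccc(Oc2ccccc2)cc1)Cn1ncc2cc(NC(=O)CO)ccc21` gives 5400 nM, and compound 1 `O=C(COc1ccc(Oc2ccccc2)cc1)Cn1ncc2cc(C(=O)O)ccc21` gives 55 nM. The measured steps are a 29-fold higher number from compound 1 to compound 3 (1.46 log units; beyond the scatter), a 98-fold higher number from compound 1 to compound 2 (1.99 log units; beyond the scatter) and a 3.4-fold lower number from compound 2 to compound 3 (0.53 log units; beyond the scatter). Compound 4 `O=C(COc1ccc(Oc2ccccc2)cc1)Cn1ncc2cc(C(=O)NS(=O)(=O)c3ccccc3)ccc21` carries the change ((phenylsulfonyl)carbamoyl in place of (ethylcarbamoyl)amino on an aromatic carbon). The step that bears on it is a 29-fold higher number from compound 1 to compound 3 (1.46 log units; beyond the scatter), in which the carbonyl attached directly to the aromatic carbon in compound 1 was lost; compound 4 reinstates such a carbonyl on that aromatic carbon, so a large step back towards compound 1 is expected in this assay, though not necessarily the whole way. The expected step is an 11-fold lower number from compound 3 to compound 4 (1.03 log units; beyond the scatter). Compound 4 is estimated at 150 nM, within 30 nM to 800 nM.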

Compound 4, half-maximal inhibitory concentration: 4700 nM
The estimate for compound 4 lay 31-fold (1.50 log units) below the measured number, and the stated range ends below it.
By their numbers in this assay, from the lowest: compound 1; then compound 3; then compounds 4 and 2 (each within the scatter of the next).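

A carbonyl on this aromatic carbon is not enough to hold the number of compound 1: replacing the hydroxy of its carboxy with (phenylsulfonyl)amino gives an 85-fold higher number from compound 1 to compound 4 (1.93 log units; beyond the scatter) in this assay. Replacing the (ethylcarbamoyl)amino of compound 3 gives no recovery, but a 2.9-fold higher number from compound 3 to compound 4 (0.47 log units; beyond the scatter). The (phenylsulfonyl)carbamoyl and ((hydroxymethyl)carbonyl)amino groups are not separated, with a 1.1-fold lower number from compound 2 to compound 4 (0.06 log units; within the scatter). No measurement shown here accounts for these steps. Open, as far as these compounds go, is whether a methylsulfonyl in place of the phenylsulfonyl, or a primary amide or tetrazole in place of the carboxy, stays nearer compound 1 or compound 4.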